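The source may hold more compounds than are shown below. What is called first, only, known or untested is meant among the compounds shown, and "the series" means these compounds.

Series notes. In an assay on HEK293 cells for inhibition of Steryl-sulfatase (Homo sapiens), tested at 0.1 uM (on this read-out higher numbers stand for a stronger effect at the one concentration tested and lower numbers for a weaker effect), compound 1 `NS(=O)(=O)Oc1ccc2c(c1)CN(C(=O)c1cccc(N3CCCCC3)c1)CC2` gives 1%, compound 2 `CN(C)CCN(CCN(C)C)c1cccc(C(=O)N2CCc3ccc(OS(N)(=O)=O)cc3C2)c1` gives 0%, and compound 3 `NS(=O)(=O)Oc1ccc2c(c1)CN(C(=O)c1cccc(N3CCc4ccccc4C3)c1)CC2` gives 24.1%. Compound 3 stands highest of the three, with compound 1 nearest and compound 2 furthest, both beyond the scatter. The two steps into compound 3 are a number 23.1 percentage points higher from compound 1 to compound 3 (beyond the scatter) and a number 24.1 percentage points higher from compound 2 to compound 3 (beyond the scatter); the step of a number 1 percentage points lower from compound 1 to compound 2 (within the scatter) is within the scatter. Compound 4 `CN(CCN1CCCCC1)c1cccc(C(=O)N2CCc3ccc(OS(N)(=O)=O)cc3C2)c1` differs from compound 3 as follows: methyl(2-(piperidin-1-yl)ethyl)amino in place of 1,2,3,4-tetrahydroisoquinolin-2-yl on an aromatic carbon. Within the data shown here, the entering group resembles those of compounds 1 and 2 in that it is not the tetrahydroisoquinolinyl present in compound 3, the only member so far that stands out. A drop back toward the values of compounds 1 and 2 is therefore expected in this assay, as a number 20.1 percentage points lower from compound 3 to compound 4 (beyond the scatter). Compound 4 is estimated at 4%, with a range from 0% to 15%.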

Compound 4, a percentage reported as inhibition, at one concentration (the size of the read-out at that concentration, not a potency): 24.5%
For compound 4 the middle estimate is 20.5 percentage points below the measured one, outside the stated range (above it).
By their numbers in this assay, from the lowest: compounds 2 and 1 (each within the scatter of the next); then compounds 3 and 4 (each within the scatter of the next).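

In this assay, an aromatic ring in the group at this position is not needed to reach the level of compound 3: the step is a number 0.4 percentage points higher from compound 3 to compound 4 (within the scatter). The piperidin-1-yl ring carried on the methyl(ethyl)amino chain also separates from the same ring set directly on the aromatic carbon, with a number 23.5 percentage points higher from compound 1 to compound 4 (beyond the scatter), and from the bis(2-(dimethylamino)ethyl)amino group, with a number 24.5 percentage points higher from compound 2 to compound 4 (beyond the scatter). Nothing on hand accounts for these steps. From the compounds shown here alone, whether a longer chain or a morpholine in place of the piperidine holds this level stays open. So does what a carboxylic acid on the chain would do.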